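A few compounds are considered here, and "the series" means these few. Any claim that something is new, unique, unknown or untested is made for them only; others in the source may bear on it.

In a functional assay on K562 cells (Homo sapiens) for inhibition, read by MTT assay, with a stated time of 48 h (a lower number here means a stronger inhibitor, a higher number a weaker inhibitor), compound 1 (`CC(C)(C)OC(=O)N1C[C@@H](n2cc(-c3ccc(N)nc3)nn2)C[C@H]1C(=O)Nc1ccc(Cl)c(C(F)(F)F)c1`) gives 4710 nM and compound 2 (`CC(=O)Nc1ccc(-c2cn([C@@H]3CN[C@H](C(=O)Nc4ccc(Cl)c(C(F)(F)F)c4)C3)nn2)cn1`) gives 8980 nM and that gap lies within the usual scatter of repeated measurements. Compound 2 therefore stands level with compound 1, and neither can be ranked above the other. The two differ in more than one place, so this pair does not reveal what any single change does.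

Compound 3 (`CC(C)(C)C(=O)Nc1ccc(-c2cn([C@@H]3CN[C@H](C(=O)Nc4ccc(Cl)c(C(F)(F)F)c4)C3)nn2)cn1`) has not yet been measured. It matches compound 2 except for one swap: tert-butyl in place of methyl on a carbonyl carbon. Within the data shown here, no measured pair shows this swap, so any forecast rests on thin evidence. Compound 2 at 8980 nM and compound 1 at 4710 nM remain within the scatter despite differing in more than one place, so only a small step is expected here. It may lean slightly toward a stronger inhibitor, but it is not expected to clear the scatter. The estimated step is a 1.4-fold lower number from compound 2 to compound 3 (0.14 log units; within the scatter) and it remains only an expectation. For compound 3 the estimate is 6500 nM with an expected range from 2500 nM to 16000 nM as the likely span.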

Compound 3, half-maximal inhibitory concentration: 43800 nM
Compound 3: middle estimate off by 6.7-fold (0.83 log units), on the low side, and the stated range ends below it.
By their numbers in this assay, from the lowest: compounds 1 and 2 (each within the scatter of the next); then compound 3.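

In this assay, the swap of methyl for tert-butyl on this carbonyl carbon gives a 4.9-fold higher number from compound 2 to compound 3 (0.69 log units; beyond the scatter), a step beyond the scatter toward a weaker inhibitor. Among these compounds, this is the first single-place comparison, and it shows that the group at this position is not a matter of indifference: the read-out responds to it even though the rest of the molecule stays the same. The change goes from 1 heavy atom to 4, all carbon, with no ring, hydrogen-bond donor, hydrogen-bond acceptor or net charge entering or leaving, and no measurement at hand explains why the number rises.

Going by these compounds, with only methyl and tert-butyl compared, it remains open whether the number climbs gradually along this series or rises sharply only at tert-butyl, which ethyl or isopropyl on the same carbonyl carbon could help to settle. On these data alone, it is also open how a group containing a heteroatom, such as an amine on that carbon, would compare with the methyl of compound 2.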